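A few compounds are considered here, and "the series" means these few. Any claim that something is new, unique, unknown or untested is made for them only; others in the source may bear on it.

Working notes on the series. Compound 1 `COc1cccc(S(=O)(=O)NC2=NCCN2C(=S)SN2CCn3c2nsc3=S)c1` opens the set. In a functional assay on KYSE-510 cells (Homo sapiens) for antiproliferative activity, read by crystal violet staining, with a stated time of 96 h (a higher number here means a weaker inhibitor of growth, a lower number a stronger inhibitor of growth), compound 1 gives >= 20000 nM, which is a limit of the assay and not a number. Compound 2 `O=S(=O)(NC1=NCCN1C(=S)SN1CCn2c1nsc2=S)c1ccc(Cl)cc1` carries 4-chlorophenyl in place of 3-methoxyphenyl on a sulfonyl sulfur. In this assay compound 2 gives >= 20000 nM, again a limit rather than a number. The step that the two limits leave unreadable from compound 1 to compound 2 is therefore of unreadable size, since both ends sit at the limit. Where compound 2 stands on the numbers shown is thus only a floor: it sits at the limit of >= 20000 nM in this assay, at which 2 of the 2 values shown sit, and no value shown lies anywhere else.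

Compound 3 `O=S(=O)(NC1=NCCN1C(=S)SN1CCn2c1nsc2=S)c1ccc(Cl)cc1Cl` differs from compound 2 by chloro in place of hydrogen on an aromatic carbon. For the measured compounds named here, the single measured step bears on this change only in that it too alters the aryl group on the sulfonyl sulfur, and it gives no readable size or direction. The expected step that the limit leaves unreadable from compound 2 to compound 3 for compound 3 is accordingly none beyond the scatter, because both measured compounds sit at the limit of >= 20000 nM in this assay, at which 2 of the 2 values shown sit. Compound 3 is estimated at 25000 nM in this assay, in the range 8000 nM to 80000 nM.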

Compound 3, concentration for 50% growth inhibition: >= 20000 nM
Compound 3 was reported as a limit; the forecaster's own chance of this, stated with the estimate: 80%; the middle value lies beyond the limit too.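

In this assay compound 3 gives >= 20000 nM, again a limit of the assay and not a number. No step among compound 1, compound 2 and compound 3 can be read, because all three share one limit: the limit of >= 20000 nM in this assay, at which 3 of the 3 values shown sit.

The compounds shown leave open whether any of these aryl groups on the sulfonyl sulfur changes growth inhibition, and by how much.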